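The source may hold more compounds than are shown below. What is called first, only, known or untested is meant among the compounds shown, and "the series" means these compounds.

Measured so far:
Compound 1 `C/C=C1/[C@H](O[C@@H]2O[C@H](CO)[C@@H](O)[C@H](O)[C@H]2O)OC=C(C(=O)OC)[C@H]1CC(=O)O`. In a functional assay on SK-BR-3 cells (Homo sapiens) for antiproliferative activity, read by MTT assay, with a stated time of 72 h (on this read-out lower numbers stand for stronger inhibition and higher numbers for weaker inhibition), compound 1 returns only the assay limit > 15000 nM.
Compound 2 `C/C=C1/[C@H](O[C@@H]2O[C@H](COC(C)=O)[C@@H](OC(C)=O)[C@H](OC(C)=O)[C@H]2OC(C)=O)OC=C(C(=O)O)[C@H]1CC(=O)O`. In this assay compound 2 likewise returns only a limit, > 20000 nM.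
Compound 3 `C/C=C1/[C@H](O[C@@H]2O[C@H](COC(C)=O)[C@@H](OC(C)=O)[C@H](OC(C)=O)[C@H]2OC(C)=O)OC=C(C(=O)OC)[C@H]1CC(=O)OCCC`. In this assay compound 3 gives a number, 6600 nM.

Compound 1 therefore stands at a limit, not at a number; two of the three values are limits (the limit of > 15000 nM in this assay, at which 1 of the 3 values shown sits, (the limit of > 20000 nM in this assay, at which 1 of the 3 values shown sits)), and only compound 3 yields a measurable value. Compound 4 `C/C=C1/[C@H](O[C@@H]2O[C@H](CO)[C@@H](O)[C@H](O)[C@H]2O)OC=C(C(=O)OC)[C@H]1CC(=O)OCc1ccccc1` is the next member: benzyl in place of hydrogen on an oxygen next to a carbonyl group. Within the data shown here, no step between measured compounds is available, so the expectation rests on compound 3, whose value 6600 nM shows that at least one member of the series reaches a number in this assay. For compound 4 a step toward stronger inhibition is expected, modest and only just beyond the scatter: an at least 1.6-fold lower number from compound 1 to compound 4 (0.22 log units; that floor lies within the scatter). Compound 4 is estimated at about 9000 nM, within 3000 nM to 30000 nM, with a real chance that only a limit is returned.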

Compound 4, half-maximal inhibitory concentration: > 15000 nM
Compound 4: no number, only a limit; the forecaster's own chance of this, stated with the estimate: 45%; middle value at least 1.6-fold (0.22 log units) from the limit.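

In this assay compound 4 returns only a limit, > 15000 nM, and compound 1 also stands at a limit, so no step can be read between them. The compounds shown leave open whether benzyl in place of hydrogen changes inhibition at all.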